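From a sulfonyl to a trifluoromethyl carbonyl on an amine

A few compounds are considered here, and "the series" means these few. Any claim that something is new, unique, unknown or untested is made for them only; others in the source may bear on it.

Of the compounds shown here, two have been tested in a functional assay on 3T3-L1 cells (Mus musculus) for inhibition, with a stated time of 20 min, tested at 20 uM; on this read-out lower numbers stand for less inhibition and higher numbers for more inhibition at the one concentration tested (going by the name of the read-out). Compound 1 `Cc1ccc(S(=O)(=O)n2cc(CN(Cc3cccc(F)c3F)C(=O)C(F)(F)F)c3ccccc32)cc1` gives -5.5%, and compound 2 `Cc1ccc(S(=O)(=O)N(Cc2cccc(F)c2F)Cc2cn(S(=O)(=O)c3ccc(F)cc3)c3ccccc23)cc1` gives -35%, the lowest of the two numbers, standing a gap beyond the usual scatter under compound 1. Compound 3 `O=C(N(Cc1cccc(F)c1F)Cc1cn(S(=O)(=O)c2ccc(F)cc2)c2ccccc12)C(F)(F)F` is not yet measured. It differs from compound 2 in one place: (trifluoromethyl)carbonyl in place of (4-methylphenyl)sulfonyl on an amine nitrogen. Compound 3 thereby carries the same (trifluoromethyl)carbonyl group on its amine nitrogen as compound 1, so a rise from compound 2 to compound 3 of a number 25 percentage points higher from compound 2 to compound 3 (beyond the scatter) is expected. For compound 3 the estimate in this assay is -10%, within -32% to 14%.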

Compound 3, a percentage reported as inhibition, at one concentration (the size of the read-out at that concentration, not a potency): -52.3%
For compound 3 the middle estimate is 42.3 percentage points above the measured one; the measured number lies below the stated range.
By their numbers in this assay, from the lowest: compound 3; then compound 2; then compound 1.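

In this assay the group on the amine nitrogen matters in this series: (trifluoromethyl)carbonyl in place of (4-methylphenyl)sulfonyl gives a number 17.3 percentage points lower from compound 2 to compound 3 (beyond the scatter). Carrying (trifluoromethyl)carbonyl there does not by itself fix the number, since fluoro in place of methyl on an aromatic carbon gives a number 46.8 percentage points lower from compound 1 to compound 3 (beyond the scatter), a large step. No measured evidence here explains either step. Still open, on these data alone, is how an acetyl group on the amine nitrogen, or a chloro or methoxy group on that aromatic carbon, would read.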